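Capping the phenol of compound 2 with a trimethylpyrazinylmethyl

The compounds below may be only part of what the source reports. "The series", "measured", "known", "first", "only" and "open" are said of these compounds alone.

Measured compounds:
compound 1, `COc1cc(CNC(=O)/C=C/c2ccccc2)ccc1O`: 3660 nM
compound 2, `COc1cc(CNC(=O)/C=C/c2ccccc2O)ccc1O`: 9760 nM

Compound 2 gives the higher of the two numbers in a functional assay on SH-SY5Y cells (Homo sapiens) for cytotoxicity, read by MTT assay, with stated times of 24 h and 4 h; a higher number here means that more compound is needed for the effect, a lower number that less compound is needed; its nearest neighbour, compound 1, lies below it by a 2.7-fold higher number from compound 1 to compound 2 (0.43 log units; beyond the scatter), a step that introduced a hydroxy in place of hydrogen on an aromatic carbon. Compound 3, `COc1cc(CNC(=O)/C=C/c2ccccc2OCc2nc(C)c(C)nc2C)ccc1O`, differs from compound 2 by (3,5,6-trimethylpyrazin-2-yl)methyl in place of hydrogen on an oxygen on an aromatic ring. Within the data shown here, no measured step touches this oxygen once it is substituted; the only known step, from compound 1 to compound 2, concerns the arrival of the hydroxy itself and does not tell what a group placed on it will do. The expectation for compound 3 in this assay is therefore a step of uncertain direction, a 1.6-fold lower number from compound 2 to compound 3 (0.21 log units; within the scatter), most likely within the scatter. Compound 3 is estimated at 6000 nM, with a range from 1800 nM to 20000 nM.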

Compound 3, half-maximal effective concentration: 12000 nM
Estimate against measurement, compound 3: 2.0-fold (0.30 log units) below; low and high end bracket the measured number.
By their numbers in this assay, from the lowest: compound 1; then compounds 2 and 3 (each within the scatter of the next).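

In this assay, placing (3,5,6-trimethylpyrazin-2-yl)methyl in place of hydrogen on this oxygen gives a 1.2-fold higher number from compound 2 to compound 3 (0.09 log units; within the scatter). The earlier step, a 2.7-fold higher number from compound 1 to compound 2 (0.43 log units; beyond the scatter), showed only what the arrival of the hydroxy does; this one shows that the hydrogen on that oxygen can give way to a group of 10 heavy atoms, including a six-membered aromatic ring, with no change beyond the scatter. The compounds shown offer no measurement that explains this result.

As far as these compounds go, it remains open whether a small methyl, a chain ending in a dimethylamino group, or a carboxymethyl group on the same oxygen would also stay within the scatter. A plain benzyl group there would be needed to tell whether the two ring nitrogens of the entering group play any part in this result.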